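Hydroxamic acid series: amide cap variation at the carbonyl

The compounds below may be only part of what the source reports. "The series", "measured", "known", "first", "only" and "open" are said of these compounds alone.

Measured so far:
compound 1, `Cc1ccc(C(=O)NCc2ccc3cc(C(=O)NO)sc3c2F)s1`: 120 nM
compound 2, `Cc1cc(C(=O)NCc2ccc3cc(C(=O)NO)sc3c2F)oc1C`: 470 nM

In a functional assay on HCT-116 cells (Homo sapiens) for antiproliferative activity, read by resazurin assay, with a stated time of 5 days (on this read-out lower numbers stand for stronger inhibition and higher numbers for weaker inhibition), compound 1 gives the lower of the two numbers recorded, and compound 2 gives 470 nM. The one step known, a 3.9-fold higher number from compound 1 to compound 2 (0.59 log units; beyond the scatter), is a cap exchange on the carbonyl carbon and is the only measured change of this kind in the series.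

Compound 3, `COc1ccc(C(=O)NCc2ccc3cc(C(=O)NO)sc3c2F)cc1`, is not yet measured. Its change from compound 1 is 4-methoxyphenyl in place of 5-methylthiophen-2-yl on a carbonyl carbon. The step from compound 1 to compound 2 is the only one that bears on it: a cap exchange on the same carbonyl carbon, which raised the number modestly. Another cap exchange is therefore expected to leave the shared core's activity in the same region, with a modest rise as the likelier direction: compound 3 is expected to show a step of a 2.1-fold higher number from compound 1 to compound 3 (0.32 log units; beyond the scatter). Compound 3 is estimated at 250 nM, with a range from 90 nM to 700 nM.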

Compound 3, half-maximal inhibitory concentration: 50 nM
Compound 3: middle estimate off by 5.0-fold (0.70 log units), on the high side, outside the stated range (below it).
By their numbers in this assay, from the lowest: compound 3; then compound 1; then compound 2.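

In this assay a cap exchange on this carbonyl carbon can lower the number as well as raise it: a 2.4-fold lower number from compound 1 to compound 3 (0.38 log units; beyond the scatter) runs against a 3.9-fold higher number from compound 1 to compound 2 (0.59 log units; beyond the scatter) and so gives the position no single direction across these three compounds. A five-membered aromatic ring with 1 hetero atom is also not required here, since the 4-methoxyphenyl cap, a six-membered aromatic ring of carbon only, gives the lowest number of the three. Going by these compounds alone, the caps at this one position span a wide range, with a 9.4-fold lower number from compound 2 to compound 3 (0.97 log units; beyond the scatter) as the largest step so far. No measurement shown bears on why the caps fall in this order.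

As far as these compounds go, it remains open whether the ring or the methoxy group accounts for the step, as the change from compound 1 to compound 3 alters both at once. Also open, from the compounds shown here alone, is how a 4-aminophenyl or 4-carboxyphenyl cap on the same carbonyl carbon would read.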